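Pyridin-2-yl Replacing 4-Chlorophenyl: Expected Inhibition of Acid Ceramidase

The compounds below may be only part of what the source reports. "The series", "measured", "known", "first", "only" and "open" are said of these compounds alone.

Measured so far, in an assay on isolated protein for inhibition of acid ceramidase (Homo sapiens), read by LC-MS, with a stated time of 1 h; on this read-out higher numbers stand for weaker inhibition and lower numbers for stronger inhibition:
compound 1 `CCCCCNC(=O)n1c(-c2ccccc2)coc1=O` gives 25 nM
compound 2 `Cc1oc(=O)n(C(=O)NCCCCc2ccccc2)c1-c1ccccc1` gives 42 nM
compound 3 `O=C(NCCCCc1ccccc1)n1cc(-c2ccc(Cl)cc2)oc1=O` gives 83 nM

Compound 3 shows the highest number of the three in this assay. Its gap to compound 2 lies within the usual scatter, so the two cannot be told apart. Its gap to compound 1 lies beyond the scatter, so compound 1 is the stronger inhibitor of the pair.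

Compound 4 `O=C(NCCCCc1ccccc1)n1cc(-c2ccccn2)oc1=O` is not yet measured. It differs from compound 3 in one place: pyridin-2-yl in place of 4-chlorophenyl on an aromatic carbon. Within the data shown here, no pair among the measured compounds shows this particular change, so there is no measured step to lean on. Since the change is confined to the aromatic group and the rest of the molecule is kept, the expectation is a step from compound 3 to compound 4 of a 1.3-fold higher number from compound 3 to compound 4 (0.12 log units; within the scatter), that is, nothing beyond the scatter in either direction. Compound 4 is therefore estimated at 110 nM in this assay, with a range from 35 nM to 350 nM.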

Compound 4, half-maximal inhibitory concentration: 25 nM
Compound 4: middle estimate off by 4.4-fold (0.64 log units), on the high side, and the stated range ends above it.
By their numbers in this assay, from the lowest: compounds 1, 4, 2 and 3 (each within the scatter of the next, the first and the last beyond it).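

Among these compounds, replacing 4-chlorophenyl with pyridin-2-yl on the aromatic carbon next to the ring oxygen gives a 3.3-fold lower number from compound 3 to compound 4 (0.52 log units; beyond the scatter) in this assay and is the first single change that can be read in this set. It shows that inhibition responds to the choice of aromatic group at this position, and that a ring with one nitrogen and no chlorine gives stronger inhibition here than 4-chlorophenyl does. No measurement at hand accounts for the shift.

Still open, from the compounds shown here alone, is whether the gain goes with adding the ring nitrogen or with losing the chlorine, and whether it depends on where that nitrogen sits. A plain phenyl or a pyridin-3-yl group at this same place, with the rest of compound 4 kept, would bear on both questions.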